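The source may hold more compounds than are shown below. What is called first, only, known or untested is meant among the compounds shown, and "the series" means these compounds.

Of the compounds shown here, three sharing one core have been measured. Compound 1 `Cc1nc2c3ccccc3ccc2c2nc3c(ccc4ccccc43)c(-c3nccnc3N)c12` gives 1210 nM in a functional assay on HeLa cells (Homo sapiens) for cytotoxicity, read by MTT assay, with a stated time of 48 h; on this read-out higher numbers stand for weaker inhibition and lower numbers for stronger inhibition; compound 2 `Cc1nc2c3ccccc3ccc2c2nc3c(ccc4ccccc43)c(-c3cc([N+](=O)[O-])ccc3N)c12` gives 5770 nM; compound 3 `Cc1ccc(-c2c3ccc4ccccc4c3nc3c2c(C)nc2c4ccccc4ccc32)cc1` gives 72200 nM, the highest of the three numbers. The steps among them run a 4.8-fold higher number from compound 1 to compound 2 (0.68 log units; beyond the scatter), a 60-fold higher number from compound 1 to compound 3 (1.78 log units; beyond the scatter) and a 13-fold higher number from compound 2 to compound 3 (1.10 log units; beyond the scatter). Compound 4 `Cc1nc2c3ccccc3ccc2c2nc3c(ccc4ccccc43)c(-c3cc(O)nc4ccccc34)c12` differs from compound 3 by 2-hydroxyquinolin-4-yl in place of 4-methylphenyl on an aromatic carbon. Going by the values given here, the steps that bear on this are the two that lead into compound 3, where an amino-bearing aryl group gave way to 4-methylphenyl and the number rose by a large amount each time; moving back from 4-methylphenyl to an aryl group that again carries a hydrogen-bond donor, compound 4 is expected to show a large drop, a 14-fold lower number from compound 3 to compound 4 (1.16 log units; beyond the scatter). Compound 4 is estimated at 5000 nM, with a range from 1500 nM to 20000 nM.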

Compound 4, half-maximal inhibitory concentration: 4880 nM
Beside the measured number, compound 4's estimate is 1.0-fold (0.01 log units) above it, and the stated range covers the measured number.
By their numbers in this assay, from the lowest: compound 1; then compounds 4 and 2 (each within the scatter of the next); then compound 3.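

In this assay, a fused two-ring group on this carbon, opposite the ring nitrogen, also lowers the number, with a 15-fold lower number from compound 3 to compound 4 (1.17 log units; beyond the scatter), so an amino-bearing aryl group is not the only replacement for 4-methylphenyl that does so. The 2-hydroxyquinolin-4-yl group stands level with 2-amino-5-nitrophenyl, with a 1.2-fold lower number from compound 2 to compound 4 (0.07 log units; within the scatter), but does not reach 3-aminopyrazin-2-yl, with a 4.0-fold higher number from compound 1 to compound 4 (0.61 log units; beyond the scatter). Nothing available explains these steps. The compounds shown leave open whether the hydroxyl, the ring nitrogen or the second ring carries the effect. An unsubstituted quinolin-4-yl or a 4-hydroxyphenyl group would help separate them.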